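From ethyl to tert-butyl on compound 1

The source may report more compounds than this note shows. Statements on the series, on what has been measured and on what is new or still open speak of the compounds shown alone.

In a functional assay on HeLa cells (Homo sapiens) for inhibition, read by CCK-8 assay, with a stated time of 72 h, tested at 2 uM (a lower number here means less inhibition of growth, a higher number more inhibition of growth at the concentration tested), compound 1 (`CCc1ccc(SCc2ccc(/C=C/C(=O)Nc3ccccc3N)cc2)cc1`) gives 3.96% and so offers a low starting number. Compound 3 (`Nc1ccccc1NC(=O)c1ccc(CSc2ccc(C(F)(F)F)cn2)cc1`) gives 11.5% and cannot be told apart from compound 1, since the two lie within the usual scatter. Compound 2 (`Nc1ccccc1NC(=O)c1ccc(CSc2cccc(F)c2)cc1`) gives 22.5% and stands above compound 1 by more than that scatter.

Compound 4 (`CC(C)(C)c1ccc(SCc2ccc(/C=C/C(=O)Nc3ccccc3N)cc2)cc1`) has not yet been measured in this assay and carries tert-butyl in place of ethyl on an aromatic carbon with the rest of compound 1 unchanged. Going by the values given here, no two measured compounds differ in just one place, so the data give no direct guide to the size of such a step. The expectation therefore starts from compound 1 at 3.96% and foresees no shift beyond the scatter. The estimated step of a number 3 percentage points higher from compound 1 to compound 4 (within the scatter) is small and could fall either way. For compound 4 the expected value is 7% with an estimated range from 0% to 20% in this measurement.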

Compound 4, percent growth inhibition at one concentration: 17.5%
For compound 4 the middle estimate is 10.5 percentage points below the measured one; the measured number falls inside the stated range.
By their numbers in this assay, from the lowest: compounds 1, 3, 4 and 2 (each within the scatter of the next, the first and the last beyond it).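

In this assay, going by these compounds alone, tert-butyl in place of ethyl gives a number 13.5 percentage points higher from compound 1 to compound 4 (beyond the scatter) and provides the first reading of a change in just one place. The number at this position therefore responds to the group it carries, even though both groups contain only carbon and neither brings a ring, a hydrogen-bond donor or acceptor, or a charge. The data at hand offer no explanation for the step.

Within the data shown here, with only this one pair, it remains open whether the number follows the size of the group or something specific to tert-butyl, and a methyl, an isopropyl, a methoxy or an amine at the same position would help to tell these apart. Going by these compounds, it also remains open whether the step would hold at other concentrations, as each number here comes from a single concentration.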